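A few compounds are considered here, and "the series" means these few. Any claim that something is new, unique, unknown or untested is made for them only; others in the source may bear on it.

Measured so far in an assay on CHO cells with metabotropic glutamate receptor 2 (Homo sapiens) as the target, read by FLIPR; a lower number here means that less compound is needed, a higher number that more compound is needed for the effect: compound 1 `Cn1c(CN2CCC(c3ccccc3)CC2)nc2ccccc21` gives 200 nM; compound 2 `FC(F)(F)c1ccc(Cl)nc1N1CCN(Cc2nc3ccccc3[nH]2)CC1` gives 12600 nM; compound 3 `FC(F)(F)c1ccc(Cl)nc1N1CCN(Cc2nc3ccccc3n2Cc2ccccc2)CC1` gives 126 nM.

Going by the values given here, compound 3 holds the lowest number of the three, but its gap to compound 1 lies within the scatter, so the two cannot be ordered; only compound 2 stands clearly apart, a 100-fold lower number from compound 2 to compound 3 (2.00 log units; beyond the scatter) marking the one measured step in this set.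

Compound 4 `CCCn1c(CN2CCN(c3nc(Cl)ccc3C(F)(F)F)CC2)nc2ccccc21` is compound 3 with ethyl in place of phenyl on a saturated chain carbon bound to an aromatic nitrogen. Among the compounds with values here, the single step on record, from compound 2 to compound 3, concerns the substituent on the aromatic nitrogen, going from hydrogen to benzyl, and was large; it shows that some group on that nitrogen matters greatly, but not whether a phenyl ring at the end of the chain is what carries it. Compound 1, with a short alkyl on its aromatic nitrogen and a different saturated ring, sits close to compound 3. On this basis a propyl is expected to lose little, if anything: for compound 4 the estimate in this assay is 250 nM (range 90 nM to 900 nM), a step of a 2.0-fold higher number from compound 3 to compound 4 (0.30 log units; within the scatter) that is expected to stay near or just beyond the scatter.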

Compound 4, half-maximal effective concentration: 2510 nM
Compound 4: middle estimate off by 10-fold (1.00 log units), on the low side; measured number above the stated range.
By their numbers in this assay, from the lowest: compounds 3 and 1 (each within the scatter of the next); then compound 4; then compound 2.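

In this assay, the phenyl counts for more than the length of the group on the aromatic nitrogen: the change from benzyl to propyl gives a 20-fold higher number from compound 3 to compound 4 (1.30 log units; beyond the scatter) and is large. A saturated chain on that nitrogen still does better than hydrogen, with a 5.0-fold lower number from compound 2 to compound 4 (0.70 log units; beyond the scatter), so part of the large step of a 100-fold lower number from compound 2 to compound 3 (2.00 log units; beyond the scatter) is reached with propyl, while the rest appears only with benzyl. Nothing at hand gives a measured reason for either step.

Open, on these data alone, is whether the aromatic ring itself is needed, which cyclohexyl in place of phenyl would test, or whether a pyridine ring could stand in its place. Also open, as far as these compounds go, is whether a longer chain such as butyl or pentyl would close any of the gap to compound 3.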